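The compounds below may be only part of what the source reports. "The series", "measured", "known", "first", "only" and "open" are said of these compounds alone.

Measured in a functional assay (Homo sapiens) for inhibition; on this read-out lower numbers stand for stronger inhibition and higher numbers for weaker inhibition:
- compound 1 `CS(=O)(=O)c1ccc(CSc2nc(-c3ccc(F)cc3)c(-c3ccncc3)[nH]2)cc1`: 330 nM
- compound 2 `C[S+]([O-])c1ccc(CCSc2nc(-c3ccc(F)cc3)c(-c3ccncc3)[nH]2)cc1`: 500 nM
- compound 3 `Oc1cccc(CSc2nc(-c3ccc(F)cc3)c(-c3ccncc3)[nH]2)c1`: 310 nM

Compound 3 cannot be separated from the other two compounds. The data show a 1.1-fold lower number from compound 1 to compound 3 (0.03 log units; within the scatter) and a 1.6-fold lower number from compound 2 to compound 3 (0.21 log units; within the scatter).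

The next compound, compound 4 `CSc1cc(CSc2nc(-c3ccc(F)cc3)c(-c3ccncc3)[nH]2)ccc1O`, has not yet been measured. It differs from compound 3 in the group on a saturated chain carbon bound to a sulfur: 4-hydroxy-3-(methylsulfanyl)phenyl in place of 3-hydroxyphenyl on a saturated chain carbon bound to a sulfur.

The three measured compounds vary at this same place, and the remaining exchange among them, a 1.5-fold higher number from compound 1 to compound 2 (0.18 log units; within the scatter), also stays within the scatter. None of them carries 4-hydroxy-3-(methylsulfanyl)phenyl, so the data offer no direct test of this group, only a general record of small steps at this place. On that record, with compound 3 at 310 nM as the starting point, no step beyond the scatter is expected in this assay, and no direction is favoured. The expected step is a 1.1-fold lower number from compound 3 to compound 4 (0.04 log units; within the scatter). For compound 4 the estimated value is 280 nM, with an expected range of 90 nM to 850 nM.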

Compound 4, half-maximal inhibitory concentration: 280 nM
Compound 4: middle estimate and measured number agree at the digits printed, and the stated range covers the measured number.
By their numbers in this assay, from the lowest: compounds 4, 3, 1 and 2 (each within the scatter of the next).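

In this assay, 4-hydroxy-3-(methylsulfanyl)phenyl on the saturated chain carbon bound to a sulfur gives a 1.1-fold lower number from compound 3 to compound 4 (0.04 log units; within the scatter), so adding methylsulfanyl to a hydroxyphenyl group produces no step beyond the scatter at this place. The comparisons with the other two compounds, a 1.2-fold lower number from compound 1 to compound 4 (0.07 log units; within the scatter) and a 1.8-fold lower number from compound 2 to compound 4 (0.25 log units; within the scatter), also stay within the scatter, which extends the flat record to a fourth group, one that carries both a hydroxy and a methylsulfanyl substituent. No independent measurement bears on this result.

Going by these compounds, it remains open whether any group at this place can move the number beyond the scatter, for example a phenyl group carrying an amine or a carboxylic acid, or a longer chain than that of compound 2. On these data alone, because the core of compound 1 is common to all four compounds, the effect of changes elsewhere in the structure also remains open.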